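This account rests on a few compounds, and the source may have more. Where it says the series, first, only, none or still open, it means among the compounds named here.

Of the compounds shown here, three of one series have been measured in a physicochemical assay for solubility, at pH 6.5; on this read-out higher numbers stand for higher solubility and lower numbers for lower solubility. Compound 1 `CS(=O)(=O)c1cncc(-c2ccc3ncc(-c4ccc(S(=O)(=O)C5CC5)cc4)n3n2)c1` reaches only a limit of the assay, < 5000 nM. Compound 2 `CS(=O)(=O)c1cncc(-c2ccc3ncc(-c4cncc(S(C)(=O)=O)c4)n3n2)c1` gives 53000 nM in this assay. Compound 3 `CS(=O)(=O)c1ccc(-c2cnc3ccc(-c4cccc(C(=O)N5CCC(O)CC5)c4)nn23)cc1` gives 178000 nM in this assay, the higher of the two numbers, with compound 2 as its nearest neighbour and the gap between them beyond the scatter. Compound 4 `CS(=O)(=O)c1ccc(-c2cnc3ccc(-c4cccc(C(=O)NCCO)c4)nn23)cc1` has not yet been measured. It differs from compound 3 in one place: (2-hydroxyethyl)amino in place of 4-hydroxypiperidin-1-yl on a carbonyl carbon. For the measured compounds named here, no measured pair shows this change, so the direction of the step is open. The step is expected to stay within the scatter, at a 1.2-fold lower number from compound 3 to compound 4 (0.07 log units; within the scatter). Compound 4 is therefore estimated at 150000 nM in this assay, between 60000 nM and 400000 nM.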

Compound 4, solubility: > 100000 nM
Compound 4 ended at the assay's limit; the forecaster's own chance of this, stated with the estimate: 5%; the middle value is on the limit's open side.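

In this assay, for the compounds shown here, compound 4 reaches only a limit, > 100000 nM, so no step from compound 3 to compound 4 can be read. The compounds shown leave open how far, and in which direction, (2-hydroxyethyl)amino in place of 4-hydroxypiperidin-1-yl moves the number.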